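Half-life of the acyl series in this assay

A few compounds are considered here, and "the series" means these few. Any claim that something is new, unique, unknown or untested is made for them only; others in the source may bear on it.

Measured compounds:
- compound 1, `CO[C@H]1C(=O)N2C(C(=O)C(C)(C)C)=C(C)CS(=O)(=O)C12`: 106 h
- compound 2, `CO[C@H]1C(=O)N2C(C(=O)c3ccccc3)=C(C)CS(=O)(=O)C12`: 26 h
- compound 3, `CO[C@H]1C(=O)N2C(C(=O)C(C)(C)C)=C(CSC3N=NC(C)S3)[C@@H](SC3N=NC(C)S3)S(=O)(=O)C12`: 75 h

All three were run in a physicochemical assay, at pH 7.4; a higher number here means that the compound lasts longer, a lower number that the compound disappears faster. Going by the values given here, the one counted step is phenyl in place of tert-butyl on a carbonyl carbon, which gave a 4.1-fold lower number from compound 1 to compound 2 (0.61 log units; beyond the scatter). Compound 3 shares the acyl group of compound 1 but sits on a different core; how the core of compound 3 differs from the core of compound 1 is not broken down here. Compound 3 and compound 1 lie within the scatter of each other in this assay, while compound 3 stands beyond the scatter from compound 2.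

Compound 4, `CO[C@H]1C(=O)N2C(C(=O)c3ccccc3)=C(CSC3N=NC(C)S3)[C@@H](SC3N=NC(C)S3)S(=O)(=O)C12`, is not yet measured. It differs from compound 3 by phenyl in place of tert-butyl on a carbonyl carbon. The place of the change reads the same as in the pair compound 1 to compound 2, so this is the same change made on the core of compound 3. Among the compounds with values here, the expectation is a step of a 4.2-fold lower number from compound 3 to compound 4 (0.62 log units; beyond the scatter), because the only measured instance of this change, a 4.1-fold lower number from compound 1 to compound 2 (0.61 log units; beyond the scatter), lay beyond the scatter. Compound 4 is therefore estimated at 18 h in this assay, with a range of 9 h to 36 h.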

Compound 4, half-life: 1300 h
Compound 4: the middle estimate sits 72-fold (1.86 log units) below what was measured, outside the stated range (above it).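

In this assay phenyl in place of tert-butyl on a carbonyl carbon gives a 17-fold higher number from compound 3 to compound 4 (1.24 log units; beyond the scatter) on the core of the later pair, while the same change gave a 4.1-fold lower number from compound 1 to compound 2 (0.61 log units; beyond the scatter) on the other core, so the two steps point in opposite directions and both lie beyond the scatter. In this series the step therefore does not carry from one core to the other, in direction or in size, though two pairs cannot show how the change would behave on any further core. Nothing available bears on what lies behind this reversal.

Only tert-butyl and phenyl stand on the carbonyl carbon here, leaving open how a longer alkyl chain, or an acyl group bearing an amine or a carboxylic acid, would behave on either core. Also open is which feature of the core of compound 3 goes with the reversal, as the compounds shown keep its differences from the core of compound 1 together.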